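The source may report more compounds than this note shows. Statements on the series, on what has been measured and on what is new or still open speak of the compounds shown alone.

Working notes on the series. Compound 1 `O=C1O/C(=C\Cn2cc(C(F)(F)F)c(=O)[nH]c2=O)C(OCc2ccccc2)=C1OCc1ccccc1` is inhibited only weakly in a functional assay on MCF7 cells (Homo sapiens) for inhibition (a lower number here means a stronger inhibitor, a higher number a weaker inhibitor), giving 40000 nM. Compound 2 `O=C1O/C(=C\Cn2cc(Br)c(=O)[nH]c2=O)C(OCc2ccccc2)=C1OCc1ccccc1` gives 40000 nM, and the step from compound 1 to compound 2 no change at the digits printed from compound 1 to compound 2 (within the scatter) shows bromo in place of trifluoromethyl on an aromatic carbon leaves the read-out where it was. Compound 3 `O=C1O/C(=C\Cn2cc(F)c(=O)[nH]c2=O)C(OCc2ccccc2)=C1OCc1ccccc1` differs from compound 1 by fluoro in place of trifluoromethyl on an aromatic carbon. Among the compounds with values here, the only step that bears on it is no change at the digits printed from compound 1 to compound 2 (within the scatter), which lay within the scatter, so no step beyond the scatter is expected in this assay. Compound 3 is therefore estimated at 40000 nM, range 15000 nM to 100000 nM, an expected step of no change at the digits printed from compound 1 to compound 3 (within the scatter).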

Compound 3, half-maximal inhibitory concentration: 60000 nM
Beside the measured number, compound 3's estimate is 1.5-fold (0.18 log units) below it, and the stated range covers the measured number.
By their numbers in this assay, from the lowest: compounds 1, 2 and 3 (each within the scatter of the next).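

In this assay, fluoro at this position gives a 1.5-fold higher number from compound 1 to compound 3 (0.18 log units; within the scatter) and a 1.5-fold higher number from compound 2 to compound 3 (0.18 log units; within the scatter). Fluoro, bromo and trifluoromethyl therefore cannot be told apart here, although trifluoromethyl brings four heavy atoms and the two halogens one each. No available evidence accounts for this flat read-out. Still open, from the compounds shown here alone, is whether an amine, a carboxylic acid or a longer chain on this aromatic carbon would move the number beyond the scatter. The compounds shown also leave open whether any change at this position can do so.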